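This account rests on a few compounds, and the source may have more. Where it says the series, first, only, none or still open, it means among the compounds named here.

Of the compounds shown here, three of one shared core have been measured in a functional assay on cells (Leukemia cell, Homo sapiens) for cytotoxicity, read by sulforhodamine B assay, with a stated time of 48 h; a higher number here means a weaker inhibitor of growth, a lower number a stronger inhibitor of growth. Compound 1 `COc1ccc(C2CC(c3ccc4ccccc4c3)=NN2C2=NC(=O)/C(=C3\C(=O)Nc4ccccc43)S2)cc1` gives 59600 nM. Compound 2 `O=C1N=C(N2N=C(c3ccccc3)CC2c2ccc(Cl)cc2)S/C1=C1/C(=O)Nc2ccccc21` gives 70800 nM. Compound 3 `COc1ccc(C2=NN(C3=NC(=O)/C(=C4\C(=O)Nc5ccccc54)S3)C(c3ccc(Cl)cc3)C2)cc1` gives 90900 nM. Among these three numbers, that of compound 3 is the largest, but all three lie close together: the gap to compound 2 and the gap to compound 1 are each within the usual scatter, so no real separation among them is shown. Compound 2 and compound 3 differ in one place, a methoxy in place of hydrogen on an aromatic carbon, and that step is a 1.3-fold higher number from compound 2 to compound 3 (0.11 log units; within the scatter).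

Compound 4 `O=C1N=C(N2N=C(c3ccc4ccccc4c3)CC2c2ccc(Cl)cc2)S/C1=C1/C(=O)Nc2ccccc21` has not yet been measured. It differs from compound 3 by naphthalen-2-yl in place of 4-methoxyphenyl on a carbon with a double bond to nitrogen. Among the measured compounds shown here, no measured step exchanges these two groups at this position, so the only guidance is indirect: compound 1 already carries a naphthalen-2-yl group, and its number sits in the same narrow band as compound 2 and compound 3. For the measured compounds named here, the one measured step, from compound 2 to compound 3, was within the scatter. The expectation for the change from compound 3 to compound 4 is therefore no step beyond the scatter, a 1.2-fold lower number from compound 3 to compound 4 (0.08 log units; within the scatter). Compound 4 is estimated at 75000 nM, with a likely range from 35000 nM to 160000 nM.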

Compound 4, concentration for total growth inhibition: 71600 nM
For compound 4 the middle estimate is 1.0-fold (0.02 log units) above the measured one, within the range that was stated.
By their numbers in this assay, from the lowest: compounds 1, 2, 4 and 3 (each within the scatter of the next).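

With the 4-chlorophenyl group held fixed, the carbon with a double bond to nitrogen can now be read directly in this assay: naphthalen-2-yl in place of 4-methoxyphenyl gives a 1.3-fold lower number from compound 3 to compound 4 (0.10 log units; within the scatter), and naphthalen-2-yl in place of phenyl gives a 1.0-fold higher number from compound 2 to compound 4 (0.00 log units; within the scatter), so replacing either single aromatic ring with two fused aromatic rings shows no real change at this position. With naphthalen-2-yl held fixed instead, chloro in place of methoxy on an aromatic carbon gives a 1.2-fold higher number from compound 1 to compound 4 (0.08 log units; within the scatter), which extends the same absence of separation to a change at another part of the molecule. No outside measurement is available to explain why these numbers stay together.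

From the compounds shown here alone, every group compared at this position is built on aromatic rings of carbon only, so it remains open whether an amine, a carboxylic acid or a longer alkyl chain there would move the number beyond the scatter. Going by these compounds, it also remains open whether a hydroxyl group on the ring atom's 4-chlorophenyl group would produce any clear step in this assay.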